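The source may report more compounds than this note shows. Statements on the series, on what has been measured and on what is new or still open speak of the compounds shown alone.

In a functional assay on A549 cells (Homo sapiens) for antiproliferative activity, read by MTT assay, with a stated time of 72 h (on this read-out lower numbers stand for stronger inhibition and higher numbers for weaker inhibition), three compounds built on one shared core have been measured. Compound 1 (`COc1cccc(-c2ncnn2-c2cc(OC)c(OC)c(OC)c2)c1`) gives > 10000 nM, which is a limit of the assay and not a number. Compound 2 (`COc1cc(-n2ncnc2-c2cccc(Cl)c2)cc(OC)c1OC`) gives > 10000 nM, which is also a limit. Going by the values given here, compound 3 (`COc1cc(-n2ncnc2-c2ccc(SC)cc2)cc(OC)c1OC`) gives 800 nM, the only true number among the three.

Compound 4 (`COc1cc(-n2ncnc2-c2ccc(F)cc2)cc(OC)c1OC`) keeps the core but swaps one group: fluoro in place of methylsulfanyl on an aromatic carbon. Its 4-fluorophenyl takes the place of the 4-(methylsulfanyl)phenyl of compound 3.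

Among the compounds with values here, two measured steps bear on this swap, and both lead to that same 4-(methylsulfanyl)phenyl group. One is an at least 12-fold lower number from compound 1 to compound 3 (1.09 log units; beyond the scatter), and the other is an at least 12-fold lower number from compound 2 to compound 3 (1.09 log units; beyond the scatter). Both are large, yet neither tests fluoro directly, so they are only a rough guide. Losing the group may give back much of that difference. The expected change is a 5.0-fold higher number from compound 3 to compound 4 (0.70 log units; beyond the scatter), towards weaker inhibition. The estimate for compound 4 is 4000 nM, with an expected range from 800 nM to 10000 nM.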

Compound 4, half-maximal inhibitory concentration: > 10000 nM
Compound 4: only a limit was reported (the forecaster's own chance of this, stated with the estimate: 35%); middle value at least 2.5-fold (0.39 log units) away from the limit.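

In this assay, going by these compounds alone, the earlier steps changed the whole substituted phenyl ring, whereas this one keeps the place on the ring fixed and changes only the group that sits on it. Putting fluoro in place of methylsulfanyl gives an at least 12-fold higher number from compound 3 to compound 4 (1.09 log units; beyond the scatter), so having a small group at this place is not enough, and of the two groups seen here, only methylsulfanyl gives a true number. The steps from compound 1 and from compound 2 to compound 4 cannot be read, because all three values are limits and not numbers: the limit of > 10000 nM in this assay, at which 3 of the 4 values shown sit.

As far as these compounds go, it remains open whether the sulfur atom matters or the methyl on it, and an amine or a longer chain such as ethylsulfanyl at this place would help to tell. From the compounds shown here alone, how weak compound 4 really is also stays unknown.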